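The compounds below may be only part of what the source reports. "The series", "measured", "known", "first", "only" and "open" are said of these compounds alone.

Compound 1 `CC(C(=O)N1CCN(c2ccccc2)CC1)N1C(=O)CCC1=O`: 50%
Compound 2 `CCC(C(=O)N1CCN(c2cccc(C(F)(F)F)c2)CC1)N1C(=O)CCC1=O`: 50%

In a functional assay on the whole organism (strain Swiss) with Mus musculus as the target, in the maximal electroshock model, with a stated time of 0.5 h, at a dose of 300 mg/kg by the intraperitoneal route (a lower number here means a weaker effect, a higher number a stronger effect of the compound at the dose given), compound 1 gives 50%. In this assay compound 2 gives 50%. Compound 2 therefore stands level with compound 1 at the digits shown, and no change beyond the usual scatter separates the two. Among the measured compounds shown here, no step between measured compounds that differ in a single place is available, so the two values can only be read side by side.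

Compound 3 `CC(C(=O)N1CCN(c2cccc(C(F)(F)F)c2)CC1)N1C(=O)CCC1=O` has not yet been measured. It differs from compound 2 in one place: hydrogen in place of methyl on a saturated chain carbon, two bonds along the chain from an amide-type nitrogen in a ring and a carbonyl carbon. Since compound 1, which carries the same methyl-bearing chain, and compound 2, which carries the same trifluoromethyl-bearing ring, both give the same read-out, compound 3 is expected to show no step beyond the scatter, no change at the digits printed from compound 2 to compound 3 (within the scatter). For compound 3 the value expected in this assay is 50%, within a range from 25% to 75%.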

Compound 3, a percentage reported as activity, at one dose (the size of the read-out at that dose, not a potency): 100%
Beside the measured number, compound 3's estimate is 50 percentage points below it; the measured number lies above the stated range.
By their numbers in this assay, from the lowest: compounds 1 and 2 (each within the scatter of the next); then compound 3.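

With hydrogen in place of methyl on a saturated chain carbon, two bonds along the chain from an amide-type nitrogen in a ring and a carbonyl carbon, this assay shows a number 50 percentage points higher from compound 2 to compound 3 (beyond the scatter), so a single carbon at this position matters when the trifluoromethyl group is present. Trifluoromethyl in place of hydrogen on an aromatic carbon also counts when the chain is held constant, giving a number 50 percentage points higher from compound 1 to compound 3 (beyond the scatter), which the earlier pair could not show because its members differ in two places at once. Nothing available explains why either change acts as it does.

The compounds shown leave open how a propyl chain or a bare methylene at this chain carbon would read, and whether chlorine or a methoxy group could stand in for trifluoromethyl on the aromatic carbon. Read at a single dose, these values also give no potency.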